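Pyridin-4-yl to 4-methylphenyl on a carbonyl carbon

The compounds below may be only part of what the source reports. "The series", "measured", "known", "first", "only" and "open" are said of these compounds alone.

Measured in a functional assay on MCF7 cells (Homo sapiens) for antiproliferative activity, read by MTT assay, with a stated time of 72 h; a higher number here means a weaker inhibitor, a lower number a stronger inhibitor:
compound 1 `CC1=CC[C@H]2[C@H](CC[C@]2(C)O)C(C)(C)[C@@H]1CC[C@H]1[C@]2(C)CC[C@H](OC(=O)c3ccccc3)C(C)(C)O[C@H]2CC[C@@]1(C)O`: 21000 nM
compound 2 `CC1=CC[C@H]2[C@H](CC[C@]2(C)O)C(C)(C)[C@@H]1CC[C@H]1[C@]2(C)CC[C@H](OC(=O)c3ccncc3)C(C)(C)O[C@H]2CC[C@@]1(C)O`: 25300 nM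

Compound 2, at 25300 nM, stands level with compound 1 within the scatter. Compound 3 `CC1=CC[C@H]2[C@H](CC[C@]2(C)O)C(C)(C)[C@@H]1CC[C@H]1[C@]2(C)CC[C@H](OC(=O)c3ccc(C)cc3)C(C)(C)O[C@H]2CC[C@@]1(C)O` carries 4-methylphenyl in place of pyridin-4-yl on a carbonyl carbon. Among the compounds with values here, the one measured step that bears on this change is a 1.2-fold higher number from compound 1 to compound 2 (0.08 log units; within the scatter), which put pyridin-4-yl in place of phenyl at that same carbonyl carbon. Nothing beyond the scatter is therefore expected in this assay, in either direction. The expected step is a 1.1-fold lower number from compound 2 to compound 3 (0.04 log units; within the scatter). Compound 3 is estimated at 23000 nM, with an expected range of 12000 nM to 42000 nM.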

Compound 3, half-maximal inhibitory concentration: > 50000 nM
Compound 3 gave a limit, no number; the forecaster's own chance of this, stated with the estimate: 8%; middle value at least 2.1-fold (0.33 log units) away from the limit.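

The methyl on the aromatic carbon of this benzoate is not neutral, unlike the swap of phenyl for pyridin-4-yl on the same carbonyl carbon: it gives an at least 2.3-fold higher number from compound 1 to compound 3 (0.37 log units; beyond the scatter). Measured against pyridin-4-yl, 4-methylphenyl gives an at least 1.9-fold higher number from compound 2 to compound 3 (0.29 log units; that floor lies within the scatter), so that comparison alone shows no firm loss. In this assay compound 3 gives a limit and no number: the limit of > 50000 nM in this assay, at which 1 of the 3 values shown sits.

As far as these compounds go, how far compound 3 lies past that limit remains open, and with it the true size of both steps. Also open, from the compounds shown here alone, is whether 4-methoxyphenyl or 4-aminophenyl on that carbonyl carbon would track with 4-methylphenyl.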